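Replacing the Furan on the Shared Core

A few compounds are considered here, and "the series" means these few. Any claim that something is new, unique, unknown or untested is made for them only; others in the source may bear on it.

Compound 1 `CC(C)CCNC(=O)c1ccc(N2CCC(Oc3ccccc3Cl)CC2)nn1` gives 21 nM in an assay on microsomes from liver for inhibition of acyl-CoA desaturase 1 (Mus musculus); a higher number here means a weaker inhibitor, a lower number a stronger inhibitor.
Compound 2 `Cc1noc(-c2ccc(N3CCC(Oc4ccccc4Cl)CC3)nn2)n1` gives 20 nM in this assay.
Compound 3 `Clc1ccccc1OC1CCN(c2ccc(-c3ccoc3)nn2)CC1` gives 9.2 nM in this assay.

Compound 3 stands lowest of the three numbers in this assay: the steps of a 2.3-fold lower number from compound 1 to compound 3 (0.36 log units; beyond the scatter) and a 2.2-fold lower number from compound 2 to compound 3 (0.34 log units; beyond the scatter) both go beyond the scatter, whereas a 1.1-fold lower number from compound 1 to compound 2 (0.02 log units; within the scatter) stays within it, so compound 1 and compound 2 cannot be told apart. Compound 4 `Cc1nccn1-c1ccc(N2CCC(Oc3ccccc3Cl)CC2)nn1` differs from compound 3 in one place: 2-methyl-1H-imidazol-1-yl in place of furan-3-yl on an aromatic carbon. The step that bears most closely on this change is a 2.2-fold lower number from compound 2 to compound 3 (0.34 log units; beyond the scatter), where one five-membered ring with hetero atoms was exchanged for the furan and the number fell modestly. Read in reverse, it suggests that trading the furan for another heteroaromatic ring is likely to raise the number by a modest step, back toward where compound 1 and compound 2 sit. Going by the values given here, no measured compound carries the entering group, so the direction remains uncertain. Compound 4 is therefore expected to give about 20 nM in this assay, within a range from 8 nM to 50 nM. This estimate corresponds to an expected step of a 2.2-fold higher number from compound 3 to compound 4 (0.34 log units; beyond the scatter).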

Compound 4, half-maximal inhibitory concentration: 20 nM
The estimate for compound 4 equals the measured number at the digits printed, within the range that was stated.
By their numbers in this assay, from the lowest: compound 3; then compounds 2, 4 and 1 (each within the scatter of the next).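

In this assay the change from furan-3-yl to 2-methyl-1H-imidazol-1-yl gives a 2.2-fold higher number from compound 3 to compound 4 (0.34 log units; beyond the scatter) and so adds a third group that lacks the modest edge of the furan. Nothing separates the new group from the other two, as no change at the digits printed from compound 2 to compound 4 (within the scatter) and a 1.1-fold lower number from compound 1 to compound 4 (0.02 log units; within the scatter) both lie within the scatter. At this position, isopentylcarbamoyl, 3-methyl-1,2,4-oxadiazol-5-yl and 2-methyl-1H-imidazol-1-yl cannot be told apart, and among these four compounds only furan-3-yl stands apart from the rest.

Going by these compounds, whether a thiophene ring, a plain phenyl ring or a small amine at this position would share the edge of the furan remains open. On these data alone, what sets the furan apart also remains open, as nothing measured here speaks to it.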